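Cyclohexyl Replaces tert-Butyl on a Weak Hydroxamic Acid

The compounds below may be only part of what the source reports. "The series", "measured", "known", "first", "only" and "open" are said of these compounds alone.

Among three compounds tested in a functional assay on A2780cisR cells (Homo sapiens) for cytotoxicity, read by MTT assay, with a stated time of 72 h (on this read-out lower numbers stand for stronger inhibition and higher numbers for weaker inhibition), compound 1 `CC(C)(C)NC(=O)C(C)(C)N(CCCCCC(=O)NO)C(=O)c1ccccc1` gives the highest number, 579000 nM, meaning the weakest cytotoxicity of the set. Compound 2 `CCCCNC(=O)CN(CCCCCC(=O)NO)C(=O)c1ccc(N(C)C)cc1` gives 3190 nM in this assay, and compound 3 `Cc1ccc(NC(=O)CN(CCCCCC(=O)NO)C(=O)c2cc(C)cc(C)c2)cc1` gives 2180 nM; both gaps to compound 1 lie beyond the usual scatter, so compound 1 is clearly the least active of the three. Compound 4 `CC(C)(C(=O)NC1CCCCC1)N(CCCCCC(=O)NO)C(=O)c1ccccc1` keeps the core of compound 1 and changes one group: cyclohexyl in place of tert-butyl on an amide-type nitrogen. For the measured compounds named here, no measured pair isolates such a change, so only a cautious expectation is possible. The expected step is small, a 2.3-fold lower number from compound 1 to compound 4 (0.36 log units; beyond the scatter), a modest move toward lower numbers that may not clear the scatter. Compound 4 is therefore estimated at 250000 nM, within a range of 60000 nM to 800000 nM.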

Compound 4, half-maximal inhibitory concentration: 281000 nM
Compound 4: the middle estimate sits 1.1-fold (0.05 log units) below what was measured, within the range that was stated.
By their numbers in this assay, from the lowest: compounds 3 and 2 (each within the scatter of the next); then compound 4; then compound 1.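

For the compounds shown here, putting cyclohexyl in place of tert-butyl on the amide-type nitrogen gives the first direct reading of this position: in this assay the swap produces a 2.1-fold lower number from compound 1 to compound 4 (0.31 log units; beyond the scatter), a modest step. The position therefore accepts a six-membered carbon ring, yet compound 4 remains weak at 281000 nM and the core of compound 1 stays far from useful activity. No further measurement bears on why the number moved.

From the compounds shown here alone, whether a benzyl group or a chain ending in a carboxylic acid on this nitrogen would shift the number further remains open. So does whether the same swap would give a similar step on a different core.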